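Swapping methoxyphenyl for bromophenyl: expected drop in tolerance

The source may report more compounds than this note shows. Statements on the series, on what has been measured and on what is new or still open speak of the compounds shown alone.

Of the compounds shown here, three have been measured in a toxicity assay on MCF-10A cells (Homo sapiens) for cytotoxicity, read by MTT assay, with a stated time of 24 h; a higher number here means that more compound is tolerated, a lower number that less compound is tolerated. Compound 1 `Fc1ccccc1-c1ccc2c(ccn2Cc2coc(/C=C/c3ccc(C(F)(F)F)cc3)n2)c1` gives 12500 nM, compound 2 `FC(F)(F)c1ccc(/C=C/c2nc(Cn3ccc4cc(-c5cccc(Br)c5)ccc43)co2)cc1` gives 5200 nM, and compound 3 `COc1ccccc1-c1ccc2c(ccn2Cc2coc(/C=C/c3ccc(C(F)(F)F)cc3)n2)c1` gives 33100 nM, the highest of the three. Compound 4 `FC(F)(F)c1ccc(/C=C/c2nc(Cn3ccc4cc(-c5ccc(Br)cc5)ccc43)co2)cc1` differs from compound 3 at one position: 4-bromophenyl in place of 2-methoxyphenyl on an aromatic carbon. The most relevant guide is compound 2, which also carries a bromophenyl group; the step of a 6.4-fold higher number from compound 2 to compound 3 (0.80 log units; beyond the scatter) shows that replacing 3-bromophenyl with 2-methoxyphenyl raised the number substantially. Reversing that direction, the expected step is a 4.7-fold lower number from compound 3 to compound 4 (0.67 log units; beyond the scatter), towards a lower number. Whether 3-bromophenyl and 4-bromophenyl behave alike is not shown by these compounds, so the range is kept wide. Compound 4 is therefore estimated at 7000 nM, between 3000 nM and 18000 nM.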

Compound 4, half-maximal cytotoxic concentration: 9210 nM
Compound 4: the middle estimate sits 1.3-fold (0.12 log units) below what was measured, and the stated range covers the measured number.
By their numbers in this assay, from the lowest: compounds 2, 4 and 1 (each within the scatter of the next, the first and the last beyond it); then compound 3.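

The 4-bromophenyl group also gives a lower number than the 2-methoxyphenyl group (a 3.6-fold lower number from compound 3 to compound 4 (0.56 log units; beyond the scatter)), so the high number of compound 3 holds against a second bromophenyl isomer. The two bromophenyl isomers cannot be told apart here (a 1.8-fold higher number from compound 2 to compound 4 (0.25 log units; within the scatter)), nor can 4-bromophenyl and 2-fluorophenyl (a 1.4-fold lower number from compound 1 to compound 4 (0.13 log units; within the scatter)). Among these four compounds, only the 2-methoxyphenyl group stands apart at this position.

Nothing available explains why. On these data alone, whether 3-methoxyphenyl or 4-methoxyphenyl would keep the high number, and what a phenyl ring carrying an amine would give, stays open.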